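The compounds below may be only part of what the source reports. "The series", "measured", "known", "first", "only" and "open" are said of these compounds alone.

Among the compounds with values here, compound 2 `O=C(NCc1ccc(S(=O)(=O)c2ccccc2)cc1)c1ccc2nccn2c1` is the only compound here with a number rather than a limit: in a functional assay on A2780 cells (Homo sapiens) for inhibition, read by sulforhodamine B assay, with a stated time of 72 h (a higher number here means a weaker inhibitor, a lower number a stronger inhibitor), compound 2 gives 13 nM. Compound 1 `O=C(NCc1ccc(S(=O)(=O)c2ccccc2)cc1)c1cc2ncccc2s1`, which carries a different two-ring group on the carbonyl carbon, reaches only the edge of what this assay can report, since compound 1 gives > 10000 nM, a limit and not a number (the limit of > 10000 nM in this assay, at which 1 of the 2 values shown sits). Within the data shown here, the single step between the two, an at least 760-fold lower number from compound 1 to compound 2 (2.88 log units; beyond the scatter), shows how strongly the group on the carbonyl carbon can move the result. Compound 3 `O=C(NCc1ccc(S(=O)(=O)c2ccccc2)cc1)c1c[nH]c2ccncc12` has not been measured. It differs from compound 2 by a group of 9 heavy atoms (7 carbon, 2 nitrogen; one five-membered aromatic ring with 1 hetero atom, one six-membered aromatic ring with 1 hetero atom) in place of a group of 9 heavy atoms (7 carbon, 2 nitrogen; one five-membered aromatic ring with 2 hetero atoms, one six-membered aromatic ring with 1 hetero atom), on a carbonyl carbon; the two compounds hold the same atoms, joined differently. Among the measured compounds shown here, the only measured step that touches this position is an at least 760-fold lower number from compound 1 to compound 2 (2.88 log units; beyond the scatter), and it is large, so swapping this group again may well shift the result strongly, though the direction cannot be read from one step. A somewhat weaker result is expected for compound 3, about a 23-fold higher number from compound 2 to compound 3 (1.36 log units; beyond the scatter), giving an estimate for compound 3 of 300 nM in this assay, likely between 30 nM and 5000 nM.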

Compound 3, half-maximal inhibitory concentration: 2100 nM
Compound 3: middle estimate off by 7.0-fold (0.85 log units), on the low side, within the range that was stated.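

The step of a 160-fold higher number from compound 2 to compound 3 (2.21 log units; beyond the scatter) shows that, on this carbonyl carbon, the way the atoms of the two-ring group are joined can matter as much as which atoms it holds, since the two groups have the same atoms. The group in compound 3 still gives a stronger result than the sulfur-containing group of compound 1, a step that places it between the two earlier groups: an at least 4.7-fold lower number from compound 1 to compound 3 (0.67 log units; beyond the scatter). The value of compound 1 is a limit and not a number, so this step has a floor but no known full size: the limit of > 10000 nM in this assay, at which 1 of the 3 values shown sits.

The group entering in compound 3 has 1 hydrogen-bond donor and 1 hydrogen-bond acceptor where the group leaving has 0 and 2, and these compounds cannot separate that difference from the change in how the rings are joined. On these data alone, whether a single ring such as phenyl or pyridyl on this carbonyl carbon could match compound 2 in this assay also stays open.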